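The source may report more compounds than this note shows. Statements on the series, on what has been measured and on what is new or still open speak of the compounds shown alone.

Compound 1, with the structure `O=C1c2ccc(O)c(O)c2C(=O)N1Cc1ccccc1`, is the starting point here, yet in an ADME assay on HOS cells (Homo sapiens) for cytotoxicity (on this read-out lower numbers stand for stronger inhibition and higher numbers for weaker inhibition), compound 1 gives "not determined" (no result reported), so no single number is available for it. A related compound 2, built as `O=C1c2c(ccc(O)c2O)CN1Cc1cccc(F)c1`, did return a reading in this assay of 8600 nM, but compound 2 is not a single-change neighbour of compound 1, so its value only shows where this kind of chemistry can land. The move from compound 1 to compound 3, whose structure is `O=C1c2ccc(O)c(O)c2C(=O)N1Cc1cccc(Cl)c1`, is small: chloro in place of hydrogen on an aromatic carbon. Among the compounds with values here, with no measured step of this type to lean on, and with the cytotoxicity read-out typically sitting in the weak range for such compounds, the change is expected to leave the number within the ordinary scatter, with no clear direction. The estimate for compound 3 in this assay is therefore 10000 nM, expected to fall between 3000 nM and 40000 nM.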

Compound 3, half-maximal inhibitory concentration: 13300 nM
The estimate for compound 3 lay 1.3-fold (0.12 log units) below the measured number; the range from low to high includes it.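

Compound 1 gives "not determined" (no result reported) in this assay and so has no number to set against compound 3, which means no step can be read between them. Going by these compounds, what the chloro group does to this read-out stays open. No supporting evidence bears on this result.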